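Heptylcarbonyl in Place of Benzyl: an Expected Value

The source may report more compounds than this note shows. Statements on the series, on what has been measured and on what is new or still open speak of the compounds shown alone.

Measured so far:
- compound 1, `CCCCC(O)Cn1cc(CN(C)CC2CCCCC2)nn1`: 47%
- compound 2, `CCCCN(CCCC)Cc1cn(CC(O)COCc2ccccc2)nn1`: 6%

Of the compounds shown here, two have been measured in an assay on nucleic acid for inhibition of Nucleic Acid, read by fluorescence, tested at 100 uM; on this read-out lower numbers stand for less inhibition and higher numbers for more inhibition at the one concentration tested (going by the name of the read-out). Compound 1 gives 47%, and compound 2 gives 6%. Compound 2 stands at the lowest of the two numbers; its nearest neighbour, compound 1, lies higher by a gap that is beyond the usual scatter of this assay. For the measured compounds named here, no step between two measured compounds differing in a single place is available, so the structural change to be judged rests on structure alone.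

Compound 3, `CCCCCCCC(=O)OCC(O)Cn1cc(CN(CCCC)CCCC)nn1`, differs from compound 2 in one place: heptylcarbonyl in place of benzyl on an oxygen on a saturated carbon. Going by the values given here, with no comparable step measured, the size of the step from compound 2 to compound 3 in this assay is open; a small rise, not clearly beyond the scatter, is expected, and the step is estimated as a number 9 percentage points higher from compound 2 to compound 3 (within the scatter). Compound 3 is therefore expected to give about 15%, within a range from 0% to 40%.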

Compound 3, a percentage reported as inhibition, at one concentration (the size of the read-out at that concentration, not a potency): 71%
Beside the measured number, compound 3's estimate is 56 percentage points below it; measured number outside the range, above it.
By their numbers in this assay, from the lowest: compound 2; then compound 1; then compound 3.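

In this assay, heptylcarbonyl in place of benzyl on an oxygen on a saturated carbon gives a number 65 percentage points higher from compound 2 to compound 3 (beyond the scatter). For the compounds shown here, this shows that the number is sensitive to the group at this position, which no pair of compounds could show before. Going by these compounds alone, the single change removes an aromatic ring and brings in an open chain, a double bond and a hydrogen-bond acceptor, and no measurement here explains the rise.

On these data alone, whether the rise follows the carbonyl, the chain or the loss of the ring stays open, and an octyl group on the same oxygen, which has a chain but no carbonyl, would help to separate these. Compound 1 differs from compound 2 and compound 3 in more than one place, so it cannot settle the question.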